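Swapping 4-methylpiperazin-1-yl for phenoxy at the assay limit

A few compounds are considered here, and "the series" means these few. Any claim that something is new, unique, unknown or untested is made for them only; others in the source may bear on it.

Compound 1 (`CCN(CC)c1ccc(-c2cccc(Cl)c2)nn1`) gives > 25000 nM (a limit)
Compound 2 (`CN1CCN(c2ccc(-c3cccc(C(F)(F)F)c3)nn2)CC1`) gives > 25000 nM (a limit)

In an ADME assay on HaCaT cells (Homo sapiens) for antiproliferative activity, with a stated time of 48 h (on this read-out lower numbers stand for stronger inhibition and higher numbers for weaker inhibition), compound 2 gives > 25000 nM as a limit and not as a number. Compound 2 therefore stands at the limit of > 25000 nM in this assay, at which 2 of the 2 values shown sit, and neither measured compound has an exact number.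

Compound 3 (`FC(F)(F)c1cccc(-c2ccc(Oc3ccccc3)nn2)c1`) is still unmeasured. It differs from compound 2 by having phenoxy in place of 4-methylpiperazin-1-yl on an aromatic carbon, and the rest of the molecule stays the same.

Among the measured compounds shown here, no measured pair shows what a single change of this kind does, so any forecast here is cautious. Compound 1 gives > 25000 nM as a limit too, with different groups on the shared core, so the swap is expected to leave the result where it is. The expected change is a number no higher from compound 2 to compound 3 (the limit leaves the size open) and no shift beyond the usual scatter is anticipated in this assay in either direction. For compound 3 the estimated value is 25000 nM with an expected range from 9000 nM to 50000 nM as the likely span.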

Compound 3, half-maximal inhibitory concentration: > 25000 nM
Compound 3 gave a limit, no number (the forecaster's own chance of this, stated with the estimate: 75%); the middle value sits exactly at the limit.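

Compound 2 and compound 3 both sit at a limit and not at an exact number, so the step between them cannot be read. The compounds shown leave open what phenoxy in place of 4-methylpiperazin-1-yl does in this assay, and how far past the limit any of them lies: the limit of > 25000 nM in this assay, at which 3 of the 3 values shown sit.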